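Two labdane acids and a diene side chain

A few compounds are considered here, and "the series" means these few. Any claim that something is new, unique, unknown or untested is made for them only; others in the source may bear on it.

Among the measured compounds shown here, compound 1 `C=CC(=C)CC[C@@H]1[C@@]2(C)CCC[C@](C)(COC(=O)/C=C\c3ccc(O)cc3)[C@@H]2CC[C@@]1(C)O` is one of two compounds measured so far in a functional assay on HL-60 cells (Homo sapiens) for cytotoxicity, read by MTT assay, with a stated time of 48 h; on this read-out lower numbers stand for stronger inhibition and higher numbers for weaker inhibition. Compound 1 gives 14100 nM in this assay. Compound 2 `C=C1CC[C@@H]2[C@](C)(CCC[C@]2(C)C(=O)O)[C@H]1CC/C(C)=C/CO` shares neither its ester nor its hydroxylated core. For compound 2 this assay reports only a limit, > 40000 nM, so no number is known for it; it stands at the weaker edge of what this assay can resolve (the limit of > 40000 nM in this assay, at which 1 of the 2 values shown sits). Compound 3 `C=CC(=C)[C@@H](O)C[C@H]1C(=C)CC[C@@H]2[C@]1(C)CCC[C@]2(C)C(=O)O` keeps the acid core of compound 2 and changes the side chain (a group of 6 heavy atoms (5 carbon, 1 oxygen; no ring) in place of a group of 6 heavy atoms (5 carbon, 1 oxygen; no ring), on a saturated chain carbon bound to a saturated ring carbon). For the measured compounds named here, no measured pair separates this change from others, so the size of its effect is unknown. The step from compound 2 to compound 3 is expected to be small, an at least 1.1-fold lower number from compound 2 to compound 3 (0.05 log units; that floor lies within the scatter), not clearly beyond the scatter. Compound 3 is therefore estimated to give about 35000 nM in this assay, most likely between 12000 nM and 80000 nM, with a real chance that only a limit is reported again.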

Compound 3, half-maximal inhibitory concentration: > 40000 nM
Compound 3: only a limit was reported; the forecaster's own chance of this, stated with the estimate: 50%; middle value at least 1.1-fold (0.05 log units) from the limit.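

In this assay, compound 2 and compound 3 are both reported only as limits, not as numbers, so no step between them can be read: the limit of > 40000 nM in this assay, at which 2 of the 3 values shown sit.

Going by these compounds, whether compound 3's new side chain changes the activity of compound 2 at all remains open.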